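The source may hold more compounds than are shown below. What is called first, only, known or untested is meant among the compounds shown, and "the series" means these compounds.

Measured compounds:
Compound 1, `COc1cc(C2OC(c3ccc(N)c(C)c3)=NN2C(C)=O)cc(OC)c1OC`, gives 0.059 uM in a functional assay on NCI-H460 cells (Homo sapiens); a lower number here means that less compound is needed, a higher number that more compound is needed for the effect.
Compound 2, `COc1cc(C2OC(c3ccc(N(C)C)cc3)=NN2C(C)=O)cc(OC)c1OC`, gives 0.044 uM in this assay.

Compound 1 stands at the higher of the two numbers, with compound 2 nearest at a 1.3-fold lower number from compound 1 to compound 2 (0.13 log units; within the scatter), a step that does not rise above the scatter. Compound 3, `COC(=O)c1c(OC)cc(C2OC(c3ccc(N)c(C)c3)=NN2C(C)=O)cc1OC`, is not yet measured in this assay. It differs from compound 1 as follows: methoxycarbonyl in place of methoxy on an aromatic carbon. Going by the values given here, the only measured step, a 1.3-fold lower number from compound 1 to compound 2 (0.13 log units; within the scatter), alters the group on the carbon with a double bond to nitrogen and leaves the rest of the shared core untouched, so it offers no direct guide to the change in compound 3. Among the compounds with values here, no measured pair exchanges methoxy for methoxycarbonyl on an aromatic carbon of a six-membered aromatic ring of carbon only. Without precedent, the expected step for compound 3 is a 5.1-fold higher number from compound 1 to compound 3 (0.71 log units; beyond the scatter) toward a higher number, held loosely. Compound 3 is therefore estimated at 0.3 uM in this assay, with a range from 0.06 uM to 1.5 uM.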

Compound 3, concentration for half-maximal effect: 0.51 uM
For compound 3 the middle estimate is 1.7-fold (0.23 log units) below the measured one; measured number inside the range.
By their numbers in this assay, from the lowest: compounds 2 and 1 (each within the scatter of the next); then compound 3.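

In this assay, going by these compounds alone, methoxycarbonyl in place of methoxy, on the aromatic carbon ortho to two methoxy groups and para to a large group, gives an 8.6-fold higher number from compound 1 to compound 3 (0.94 log units; beyond the scatter) and is the first single exchange to pass beyond the scatter. The earlier exchange on the carbon with a double bond to nitrogen, a 1.3-fold lower number from compound 1 to compound 2 (0.13 log units; within the scatter), did not, so this aromatic carbon is the one place shown so far where a change separates the compounds. No measured information at hand bears on the reason for this rise.

On these data alone, it remains open whether the rise belongs to the ester as a whole, which a carboxylic acid, a primary amide or a hydroxymethyl group on this carbon would help to test. Also open, as far as these compounds go, is whether the same exchange has a step of similar size with the 4-(dimethylamino)phenyl group of compound 2 in place of the 4-amino-3-methylphenyl group.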